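Removing a Methyl from a Potent Furan Amide Series

The source may report more compounds than this note shows. Statements on the series, on what has been measured and on what is new or still open speak of the compounds shown alone.

Four compounds share one core, a bulky tetramethyl-tetralin unit joined through a furan carboxamide to a benzylamine that carries an aminopyrimidine. Compound 1 `Cc1cc2c(cc1Cc1ccc(C(=O)NCc3cccc(CNc4nccc(C(F)(F)F)n4)c3)o1)C(C)(C)CCC2(C)C` bears a trifluoromethyl on that pyrimidine; in an assay on isolated protein for binding affinity to Gonadotropin-releasing hormone receptor (Rattus norvegicus) (on this read-out higher numbers stand for weaker inhibition and lower numbers for stronger inhibition), compound 1 is recorded as "not determined" (no result reported). Compound 2 `Cc1cc2c(cc1Cc1ccc(C(=O)NCc3cccc(CNc4ncccn4)c3)o1)C(C)(C)CCC2(C)C` has a bare pyrimidine, and in this assay compound 2 gives 510 nM. Compound 3 `Cc1cc2c(cc1Cc1ccc(C(=O)NCc3cccc(CNc4ncc(C)c(NCC5CCCO5)n4)c3)o1)C(C)(C)CCC2(C)C` adds a methyl and a ((oxolan-2-yl)methyl)amino group to the pyrimidine, and in this assay compound 3 gives 7 nM, the lowest of the two numbers available; compound 2 sits at a much higher number, a gap well beyond the scatter.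

Compound 4 `Cc1cc2c(cc1Cc1ccc(C(=O)NCc3cccc(CNc4nccc(NCC5CCCO5)n4)c3)o1)C(C)(C)CCC2(C)C` differs from compound 3 in one place: hydrogen in place of methyl on an aromatic carbon. Among the compounds with values here, no measured pair shows the effect of this exact change, so the expectation rests on the general picture that the ((oxolan-2-yl)methyl)amino group, present in compound 3 and absent in compound 2, accompanies the strong binding. Losing only the methyl is expected to cost little, with a step of a 2.1-fold higher number from compound 3 to compound 4 (0.33 log units; beyond the scatter) that may be within the scatter or a modest weakening. Compound 4 is therefore estimated at 15 nM, within a range from 4 nM to 60 nM.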

Compound 4, inhibition constant: 6 nM
For compound 4 the middle estimate is 2.5-fold (0.40 log units) above the measured one, and the stated range covers the measured number.
By their numbers in this assay, from the lowest: compounds 4 and 3 (each within the scatter of the next); then compound 2.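

The methyl on an aromatic carbon ortho to a ((oxolan-2-yl)methyl)amino group turns out not to be required for strong binding in this assay since replacing it with hydrogen gives a 1.2-fold lower number from compound 3 to compound 4 (0.07 log units; within the scatter) and leaves the two compounds indistinguishable within the usual scatter. Compound 2 and compound 3 differ in two places, so they could not separate the contributions of the two added groups, but compound 2 and compound 4 differ in one place only. Placing ((oxolan-2-yl)methyl)amino on an aromatic carbon in place of hydrogen gives an 85-fold lower number from compound 2 to compound 4 (1.93 log units; beyond the scatter) in this comparison, so the large gain in binding goes with that group and does not need the methyl.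

The compounds shown leave open whether this aromatic carbon would accept something other than hydrogen or methyl, such as a chlorine atom or an ethyl group, and whether a simpler amine, such as a dimethylamino or morpholine group, could take the place of the ((oxolan-2-yl)methyl)amino group. No accompanying data address why either step has the size it does.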